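Triazole aryl swap, bromo to methyl, in the tosylate series

This account rests on a few compounds, and the source may have more. Where it says the series, first, only, none or still open, it means among the compounds named here.

Values in a functional assay on HL-60 cells (Homo sapiens) for cytotoxicity, read by MTT assay, with a stated time of 4 days; a lower number here means a stronger inhibitor, a higher number a weaker inhibitor:
compound 1, `C=C1C(=O)[C@]23C[C@@]1(O)CC[C@H]2c1ccc(OS(=O)(=O)c2ccc(C)cc2)c(C)c1[C@@H]3Cn1cc(-c2ccc(Br)cc2)nn1`: 1020 nM
compound 2, `COc1ccc(-c2cn(C[C@H]3c4c(ccc(OS(=O)(=O)c5ccc(C)cc5)c4C)[C@@H]4CC[C@@]5(C)C[C@]43CC5=O)nn2)cc1`: > 20000 nM
compound 3, `C=C1C[C@]23C[C@@]1(O)CC[C@H]2c1cc(Br)c(O)c(C)c1[C@@H]3Cn1cc(-c2ccc(F)cc2)nn1`: 6600 nM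

Compound 1 holds the lower of the two numeric values in this assay; compound 3 sits higher, and that gap lies beyond the usual scatter. For compound 2 the assay gives only a limit, not a number (the limit of > 20000 nM in this assay, at which 1 of the 3 values shown sits).

Compound 4, `C=C1C(=O)[C@]23C[C@@]1(O)CC[C@H]2c1ccc(OS(=O)(=O)c2ccc(C)cc2)c(C)c1[C@@H]3Cn1cc(-c2ccc(C)cc2)nn1`, awaits measurement. It differs from compound 1 by methyl in place of bromo on an aromatic carbon. Among the compounds with values here, no measured pair isolates this change, so its size rests on expectation alone: a small step, in no firm direction, likely within the scatter. From compound 1 to compound 4 the step expected in this assay is a 1.5-fold higher number from compound 1 to compound 4 (0.17 log units; within the scatter). Compound 4 is therefore estimated at 1500 nM, with a range from 500 nM to 6000 nM.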

Compound 4, half-maximal inhibitory concentration: 1110 nM
For compound 4 the middle estimate is 1.4-fold (0.13 log units) above the measured one; the range from low to high includes it.
By their numbers in this assay, from the lowest: compounds 1 and 4 (each within the scatter of the next); then compound 3. At a limit, above all of these: compound 2.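

In this assay, the swap from 4-bromophenyl to 4-methylphenyl on the triazole gives a 1.1-fold higher number from compound 1 to compound 4 (0.04 log units; within the scatter). Within the data shown here, this is the first measured pair to isolate a change at this position, and here bromo and methyl on this aromatic carbon cannot be told apart. No measured property at hand bears on this swap.

An amine or a carboxylic acid at this same aromatic carbon remains untested in the compounds shown, so the tolerance of this position beyond bromo and methyl stays open. On these data alone, whether the swap gives an equally small step on another core also stays open.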